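Exchanging pyridin-2-yl for 1,3-thiazol-2-yl on the nitrogen

The source may hold more compounds than are shown below. What is called first, only, known or untested is meant among the compounds shown, and "the series" means these compounds.

In a functional assay on SK-OV-3 cells (Homo sapiens) for cytotoxicity, read by MTT assay, with a stated time of 3 days (a higher number here means a weaker inhibitor, a lower number a stronger inhibitor), compound 1 (`CCNc1nc(SCc2nc3ccccc3[nH]2)nc(-c2ccccc2)c1C#N`) gives 7.35 nM and compound 2 (`N#Cc1c(Nc2ccccn2)nc(SCc2nc3ccccc3[nH]2)nc1-c1ccccc1`) gives 5.81 nM. Within the data shown here, these are the only two numbers so far, and they lie within the scatter of each other, so compound 2 stands level with compound 1. Compound 3 (`N#Cc1c(Nc2nccs2)nc(SCc2nc3ccccc3[nH]2)nc1-c1ccccc1`) has 1,3-thiazol-2-yl in place of pyridin-2-yl on a nitrogen on an aromatic ring. Among the measured compounds shown here, only one measured step bears on this change, a 1.3-fold lower number from compound 1 to compound 2 (0.10 log units; within the scatter), with pyridin-2-yl in place of ethyl at the same place, and it stays within the scatter. No five-membered ring has been measured there yet. A change no larger than the scatter is therefore expected in this assay, with no firm direction. The expected step is a 1.0-fold higher number from compound 2 to compound 3 (0.01 log units; within the scatter). For compound 3 the estimated value is 6 nM, with an expected range from 2.5 nM to 15 nM.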

Compound 3, half-maximal inhibitory concentration: 5.81 nM
Estimate against measurement, compound 3: 1.0-fold (0.01 log units) above; the range from low to high includes it.
By their numbers in this assay, from the lowest: compounds 2, 3 and 1 (each within the scatter of the next).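

With compound 3, a five-membered aromatic ring carrying sulfur now sits on this nitrogen in this assay, and the exchange for the six-membered pyridin-2-yl ring gives no change at the digits printed from compound 2 to compound 3 (within the scatter). Set against the ethyl group, the same ring gives a 1.3-fold lower number from compound 1 to compound 3 (0.10 log units; within the scatter). Ethyl, pyridin-2-yl and 1,3-thiazol-2-yl therefore cannot be told apart at this position, so neither the size of the aromatic ring nor the swap from an aromatic ring to a small chain separates these compounds here, and nothing available accounts for this.

The compounds shown leave open whether a free amine, a carboxylic acid or a longer chain on this nitrogen would move the number beyond the scatter. They also leave open whether the same holds when another part of the shared core is altered.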